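Amide-side variation in a fluorinated aryl sulfone series

This account rests on a few compounds, and the source may have more. Where it says the series, first, only, none or still open, it means among the compounds named here.

Measured so far in an ADME assay on microsomes from liver (Homo sapiens) for metabolic stability, with a stated time of 10 min; a higher number here means that more of the compound is left, a lower number that less of the compound is left:
compound 1 `CC[C@]1(C(=O)O)CC[C@H](C(=O)N2CC[C@](c3ccc(C(F)(C(F)(F)F)C(F)(F)F)cc3)(S(=O)(=O)c3ccc(F)cc3)C2)CC1` gives 100%
compound 2 `C[C@]1(C(=O)N2CC[C@](c3ccc(C(F)(C(F)(F)F)C(F)(F)F)cc3)(S(=O)(=O)c3ccc(F)cc3)C2)CC[C@H](C(=O)O)CC1` gives 80%
compound 3 `O=C1NC(=O)C2(CCC(C(=O)N3CC[C@](c4ccc(C(F)(C(F)(F)F)C(F)(F)F)cc4)(S(=O)(=O)c4ccc(F)cc4)C3)CC2)N1` gives 84%; 93% (2 entries)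

Compound 2 stands lowest of the two single numbers; its nearest neighbour is compound 1, and the step of a number 20 percentage points lower from compound 1 to compound 2 (beyond the scatter) is beyond the scatter. Compound 3 carries no single number but several entries (the several entries of compound 3 in this assay, 84%; 93% (2 entries)), all in the upper part of the range.

Compound 4 `O=C(N1CC[C@](c2ccc(C(F)(C(F)(F)F)C(F)(F)F)cc2)(S(=O)(=O)c2ccc(F)cc2)C1)C1(F)CCS(=O)(=O)CC1` is not yet measured. Relative to compound 2 the change is 4-fluoro-1,1-dioxothian-4-yl in place of 4-carboxy-1-methylcyclohexyl on a carbonyl carbon. Among the compounds with values here, the only measured step at the same place is a number 20 percentage points lower from compound 1 to compound 2 (beyond the scatter), a modest loss on going from ethyl to methyl on that ring. Within the data shown here, the present change is larger: the carboxy-bearing carbocycle leaves and a ring with one hetero atom and no hydrogen-bond donor enters, so no measured step covers it directly. Compound 3, also without the carboxy group, stays high. The expectation for compound 4 is therefore a return toward the upper range, a number 5 percentage points higher from compound 2 to compound 4 (within the scatter), though with wide uncertainty. Compound 4 is estimated at 85%, between 65% and 100%.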

Compound 4, percent of the compound remaining: 100%
Beside the measured number, compound 4's estimate is 15 percentage points below it; low and high end bracket the measured number.
By their numbers in this assay, from the lowest: compound 2; then compounds 1 and 4 (each within the scatter of the next).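

With the 4-fluoro-1,1-dioxothian-4-yl group on the carbonyl carbon, this assay shows a number 20 percentage points higher from compound 2 to compound 4 (beyond the scatter), and against the ethyl acid it shows no change at the digits printed from compound 1 to compound 4 (within the scatter). A high number at this position therefore does not depend on the carboxy-bearing carbocycle, and it holds for an entering group with 0 hydrogen-bond donors and a sulfur-containing ring. The loss seen with the 4-carboxy-1-methylcyclohexyl group thus does not extend to this ring, and the other compound without the carboxy group also sits high: the several entries of compound 3 in this assay, 84%; 93% (2 entries)

Still open, as far as these compounds go, is whether the fluorine contributes to the step, which a hydroxy group or an amine in its place on the same ring would test. Also open, from the compounds shown here alone, is whether a longer chain there keeps the number as high in this assay.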